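Aryl ether in place of benzylamine on the shared core

The source may hold more compounds than are shown below. What is called first, only, known or untested is meant among the compounds shown, and "the series" means these compounds.

Compound 1, `COc1cc(Nc2ncccc2-c2n[nH]c(Nc3ccccc3)n2)cc(OC)c1`, is the reference point of the set. In a functional assay on A-431 cells (Homo sapiens) (a lower number here means that less compound is needed, a higher number that more compound is needed for the effect), compound 1 gives > 10000 nM, which is a limit of the assay and not a number. Among the compounds with values here, compound 2, `Fc1ccc(CNc2ncccc2-c2n[nH]c(Nc3ccc4c(c3)OCCO4)n2)cc1F`, differs from compound 1 in more than one place, so no single step links the two. In this assay compound 2 gives "not determined" (no result reported), so there is no single number for compound 2; of the two values shown for the pair, one is the limit of > 10000 nM in this assay, at which 1 of the 2 values shown sits.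

Compound 3, `COc1cc(OC)cc(Oc2ncccc2-c2n[nH]c(Nc3ccc4c(c3)OCCO4)n2)c1`, follows from compound 2 by one exchange: 3,5-dimethoxyphenoxy in place of (3,4-difluorobenzyl)amino on an aromatic carbon. The 3,5-dimethoxyphenoxy group that enters brings back the substitution pattern seen in compound 1, while the rest of compound 2 is kept. Within the data shown here, no measured step exists for this exchange, and compound 2 itself has no number, so direction and size of the step in this assay cannot be read from the data; the only guide is the outcome for compound 1.

Compound 1 sits at the limit > 10000 nM in this assay. On that basis compound 3 is expected to land near the same limit, estimated at 8000 nM, with a range from 1500 nM to 40000 nM.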

Compound 3, half-maximal effective concentration: 3.6 nM
For compound 3 the middle estimate is 2200-fold (3.35 log units) above the measured one; measured number outside the range, below it.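

In this assay, within the data shown here, compound 3 gives 3.6 nM, while compound 2 has no single number, so no step from compound 2 to compound 3 can be read. The compounds shown leave open what the exchange of (3,4-difluorobenzyl)amino for 3,5-dimethoxyphenoxy does on its own in this assay, and which part of compound 3 its value depends on.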